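Working notes: nitro in place of methoxy, compound 4

A few compounds are considered here, and "the series" means these few. Any claim that something is new, unique, unknown or untested is made for them only; others in the source may bear on it.

Three members of the series have been measured in a functional assay on DU-145 cells (Homo sapiens) for inhibition, read by trypan blue exclusion, with a stated time of 96 h; on this read-out lower numbers stand for stronger inhibition of growth and higher numbers for weaker inhibition of growth. Compound 1 `O=C(/C(=C\c1ccc(Cl)cc1Cl)Sc1ccc(Br)cc1)c1ccc(Br)cc1` gives 1000 nM. Compound 2 `COc1cc(/C=C(/Sc2ccc(Br)cc2)C(=O)c2ccc(Br)cc2)ccc1O` gives 1000 nM, and compound 3 `O=C(/C(=C\c1ccc(I)cc1)Sc1ccc(Br)cc1)c1ccc(Br)cc1` gives 1000 nM. Compound 2 therefore stands level with compounds 1 and 3 at the digits shown: the step of no change at the digits printed from compound 1 to compound 2 (within the scatter), the step of no change at the digits printed from compound 1 to compound 3 (within the scatter) and the step of no change at the digits printed from compound 2 to compound 3 (within the scatter) all lie within the scatter, so the three different aryl groups on the double-bonded chain carbon have so far left the read-out unchanged.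

Compound 4 `O=C(/C(=C\c1ccc(O)c([N+](=O)[O-])c1)Sc1ccc(Br)cc1)c1ccc(Br)cc1` is not yet measured. It differs from compound 2 by nitro in place of methoxy on an aromatic carbon. The change sits on the same ring that was varied across compounds 1, 2 and 3, and none of those exchanges moved this assay beyond the scatter. Within the data shown here, no measured step concerns a nitro group or this exact exchange, so the bearing of the three steps is indirect only. On that basis no step beyond the scatter is expected in either direction, and the expected step is no change at the digits printed from compound 2 to compound 4 (within the scatter). The estimate for compound 4 is 1000 nM, expected to fall between 500 nM and 2000 nM.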

Compound 4, concentration for 50% growth inhibition: 1000 nM
Compound 4: middle estimate and measured number agree at the digits printed, and the stated range covers the measured number.
By their numbers in this assay, from the lowest: compounds 1, 2, 3 and 4 (each within the scatter of the next).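

Compounds 1 and 3 differ from compound 2 in the whole aryl group, whereas this step changes one substituent, ortho to a hydroxy group, and keeps the hydroxy group in place. In this assay, nitro in place of methoxy gives no change at the digits printed from compound 2 to compound 4 (within the scatter), so this position takes nitro, with 3 heavy atoms and 2 hydrogen-bond acceptors, as well as methoxy, with 2 heavy atoms and 1 hydrogen-bond acceptor, without a step beyond the scatter. No supporting data are available to interpret this flat result at this position.

On these data alone, since all four compounds read alike at the digits printed, it remains open whether any substituent at this position can move the read-out, and an amine or a carboxylic acid ortho to the hydroxy group would be a more distinct exchange to compare with compound 2. The shown compounds also leave the rest of the shared core unvaried, so nothing here tells how the read-out responds to a change outside this ring, such as a longer chain in place of either bromine-bearing aryl group.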